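This account rests on a few compounds, and the source may have more. Where it says the series, first, only, none or still open, it means among the compounds named here.

Measured compounds in the series:

- compound 1 `CCSC[C@@H](NC(=O)[C@@H](CS)Cc1ccccc1)C(=O)O`, 2.4 nM in an assay on isolated protein for inhibition of Neprilysin (Oryctolagus cuniculus); on this read-out higher numbers stand for weaker inhibition and lower numbers for stronger inhibition
- compound 2 `CC(C)(C)SC[C@@H](NC(=O)[C@H](CS)Cc1ccccc1)C(=O)O`, 231 nM
- compound 3 `CCSC[C@@H](NC(=O)C(CS)Cc1ccccc1)C(=O)O`, 6.5 nM

Compound 3 stands second highest of the three numbers. Its nearest neighbour is compound 1, at a 2.7-fold higher number from compound 1 to compound 3 (0.43 log units; beyond the scatter); the two share all atoms and bonds, and the pair differs only in that one stereocentre is drawn with a configuration in compound 1 and without one in compound 3 (the fact that one of compounds 1 and 3 is drawn with a defined configuration and the other without, at the place where they differ). Within the data shown here, compound 2 lies far higher than compound 3, and no single-point step connects it to the others.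

Compound 4 `CCCC(CS)C(=O)N[C@H](CSCC)C(=O)O` is not yet measured. Relative to compound 3 the change is ethyl in place of phenyl on a saturated chain carbon, two bonds along the chain from a carbonyl carbon. Among the measured compounds shown here, none of the measured steps touches this position; the only single-point step is the stereochemical one from compound 1 to compound 3, which says nothing about exchanging the phenyl for ethyl. The expectation therefore rests on the value of compound 3 alone, with wide uncertainty. For compound 4 a higher number than compound 3 is expected in this assay, a step of a 9.2-fold higher number from compound 3 to compound 4 (0.97 log units; beyond the scatter), with an estimate of 60 nM and a range from 10 nM to 400 nM.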

Compound 4, half-maximal inhibitory concentration: > 300 nM
Compound 4 gave a limit, no number; the forecaster's own chance of this, stated with the estimate: 2%; middle value at least 5.0-fold (0.69 log units) from the limit.
By their numbers in this assay, from the lowest: compound 1; then compound 3; then compound 2. At a limit, above all of these: compound 4.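

In this assay, among these compounds, ethyl in place of phenyl on a saturated chain carbon, two bonds along the chain from a carbonyl carbon, gives an at least 46-fold higher number from compound 3 to compound 4 (1.66 log units; beyond the scatter), the first reading of this position. Compound 4 gives > 300 nM, which is a limit and not a number: the limit of > 300 nM in this assay, at which 1 of the 4 values shown sits. Among the single-point steps shown, benzyl to propyl therefore weighs far more than the stereochemical step, a 2.7-fold higher number from compound 1 to compound 3 (0.43 log units; beyond the scatter).

As far as these compounds go, whether the loss follows the aromatic ring or the size of the group stays open, and a cyclohexyl or a longer chain such as butyl in the same place would separate the two. Also open, from the compounds shown here alone, is how compound 4 would read with a defined configuration at its undefined stereocentre.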